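This account rests on a few compounds, and the source may have more. Where it says the series, first, only, none or still open, it means among the compounds named here.

In an ADME assay on HepG2 cells (Homo sapiens) for cytotoxicity, with a stated time of 72 h (a higher number here means that more compound is needed for the effect, a lower number that less compound is needed), three compounds have been measured so far.
Compound 1 `Cc1cc(NC(=O)Nc2cc(F)ccc2F)c2ccccc2n1` gives > 25000 nM, which is a limit of the assay and not a number.
Compound 2 `Cc1cc(NC(=O)Nc2cc(Cl)cc(Cl)c2)c2ccccc2n1` gives > 25000 nM, again a limit.
Compound 3 `Cc1cc(NC(=O)Nc2ccc(C(=O)O)c(O)c2)c2ccccc2n1` gives > 25000 nM, also a limit.

Within the data shown here, compound 1 therefore sits at the limit of > 25000 nM in this assay, at which 3 of the 3 values shown sit, and with every value a limit, no step between measured compounds can be sized. Compound 4 `Cc1cc(NC(=O)Nc2cccc(F)c2)c2ccccc2n1` differs from compound 1 by hydrogen in place of fluoro on an aromatic carbon. Since compound 1 shows only a limit, > 25000 nM, no change beyond the scatter is expected from this step, a step that the limit leaves unreadable from compound 1 to compound 4. Compound 4 is accordingly expected to give about 30000 nM in this assay, within 15000 nM to 60000 nM, most likely reported only as a limit.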

Compound 4, half-maximal effective concentration: > 25000 nM
Compound 4: no number, only a limit; the forecaster's own chance of this, stated with the estimate: 85%; the middle value does not contradict the limit.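

Among these compounds, compound 4 gives > 25000 nM, which is a limit of the assay, so no step from compound 1 to compound 4 can be read: the limit of > 25000 nM in this assay, at which 4 of the 4 values shown sit. In this assay the compounds shown leave open at what concentration, if any, each of them has the effect.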